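The compounds below may be only part of what the source reports. "The series", "measured", "known", "first", "only" and "open" are said of these compounds alone.

Values measured so far in a functional assay on the whole organism (Hindlimb, strain albino) with Mus musculus as the target, in the maximal electroshock model, with a stated time of 0.5 h; a lower number here means that less compound is needed, a higher number that more compound is needed for the effect:

- compound 1 `CC(=O)N1N=C(Nc2nc3ccccc3s2)CC1c1ccccc1`: 315 umol/kg
- compound 2 `CC(=O)N1N=C(Nc2nc3ccccc3s2)CC1c1ccc(Cl)cc1`: 209 umol/kg
- compound 3 `CC(=O)N1N=C(Nc2nc3ccccc3s2)CC1OC1=CC=C1`: 382 umol/kg

Compound 1 sits in the middle of these three numbers, but it is not separated from either neighbour: a 1.5-fold lower number from compound 1 to compound 2 (0.18 log units; within the scatter) and a 1.2-fold higher number from compound 1 to compound 3 (0.08 log units; within the scatter). The remaining pair gives the same picture, with a 1.8-fold higher number from compound 2 to compound 3 (0.26 log units; within the scatter). Within the data shown here, the series so far therefore shows no change beyond the scatter.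

Compound 4 `CC(=O)N1N=C(Nc2nc3ccc([N+](=O)[O-])cc3s2)CC1c1ccccc1` keeps the core of compound 1 and has one change: nitro in place of hydrogen on an aromatic carbon. In words, this is nitro in place of hydrogen on an aromatic carbon. Among the measured compounds shown here, no measured compound carries any substituent at this part of the structure, so the evidence is indirect. For the measured compounds named here, the closest precedent is compound 2, also a replacement of hydrogen on an aromatic carbon, though at another place, with a 1.5-fold lower number from compound 1 to compound 2 (0.18 log units; within the scatter). The two steps to compound 3 concern a saturated ring carbon and bear on this change only as a sign of how flat the series has been so far.

No shift beyond the scatter is therefore expected, with a slight lean towards a lower number. The estimated step is a 1.2-fold lower number from compound 1 to compound 4 (0.07 log units; within the scatter). For compound 4 the expected value is 270 umol/kg, with an estimated range from 130 umol/kg to 550 umol/kg.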

Compound 4, dose for half-maximal effect: 216 umol/kg
Estimate against measurement, compound 4: 1.3-fold (0.10 log units) above, within the range that was stated.
By their numbers in this assay, from the lowest: compounds 2, 4, 1 and 3 (each within the scatter of the next).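

In this assay, the nitro group on the six-membered aromatic ring of carbon only, part of a fused or bridged system of two rings, gives a 1.5-fold lower number from compound 1 to compound 4 (0.16 log units; within the scatter). The step shows that this part of the structure can take a nitro group, with no hydrogen-bond donor and with 2 hydrogen-bond acceptors, without a shift beyond the scatter. Compounds 2 and 3 carry their changes elsewhere, so the absence of any step beyond the scatter now extends to a further part of the shared core, and nothing measured here speaks to what lies behind this result.

On these data alone, a single group at a single place cannot show how far this tolerance reaches, so it remains open whether an amine, a carboxylic acid or a longer chain on the same aromatic carbon would give a step beyond the scatter. As far as these compounds go, it also remains open whether the nitro group on another carbon of this ring would behave alike, and whether nitro combined with the chloro group of compound 2 would give a number beyond the scatter of compound 1.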